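The source may report more compounds than this note shows. Statements on the series, on what has been measured and on what is new or still open speak of the compounds shown alone.

Working notes on the series.

Compound 1 `Cn1c(CN2CCN(c3ccc(C(F)(F)F)cc3)CC2)nc2ccccc21` is the reference point for this step. In an assay on CHO cells with metabotropic glutamate receptor 2 (Homo sapiens) as the target, read by FLIPR (a lower number here means that less compound is needed, a higher number that more compound is needed for the effect), compound 1 gives 200 nM. Among the three measured compounds this is the second highest number. The closest neighbour is compound 3 `Cn1c(CN2CCC(c3ccccc3F)CC2)nc2ccccc21`, which in this assay gives 126 nM; the two numbers lie within the scatter of each other, so nothing can be said about an order between compound 1 and compound 3. The furthest is compound 2 `FC(F)(F)c1ccc(Cl)nc1N1CCN(Cc2nc3ccccc3[nH]2)CC1`, which in this assay gives 12600 nM, a gap well beyond the scatter. For the measured compounds named here, no pair of measured compounds differs in a single place, so no step from the measured set can be read off directly.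

Compound 4 `Cn1c(CN2CCN(c3ccc(C#N)cc3)CC2)nc2ccccc21` has not yet been measured in this assay. It differs from compound 1 as follows: cyano in place of trifluoromethyl on an aromatic carbon. Going by the values given here, no measured pair covers this kind of exchange, so the expectation rests on the position of compound 1 alone. The step is expected to be modest, if anything toward a somewhat higher number, and possibly not beyond the scatter. The number expected for compound 4 in this assay is 400 nM, with a range from 130 nM to 1300 nM. The step that this estimate means is a 2.0-fold higher number from compound 1 to compound 4 (0.30 log units; within the scatter), given as an expectation only.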

Compound 4, half-maximal effective concentration: > 12500 nM
Compound 4: no number, only a limit; the forecaster's own chance of this, stated with the estimate: 5%; middle value at least 31-fold (1.49 log units) from the limit.
By their numbers in this assay, from the lowest: compounds 3 and 1 (each within the scatter of the next); then compound 2.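

In this assay compound 4 gives > 12500 nM as a limit of the assay and not a number. For the compounds shown here, the exchange of trifluoromethyl for cyano on an aromatic carbon, para to a large group, gives the first step that can be read from a single change, an at least 62-fold higher number from compound 1 to compound 4 (1.79 log units; beyond the scatter) and so a large one, with the rest of the structure unchanged; this place on the aromatic ring is therefore not indifferent to which group it carries, which the earlier compounds, none of them differing in one place, could not show. The step is open-ended on its upper side, so its full size stays unknown, and the reading rests on this one pair: the limit of > 12500 nM in this assay, at which 1 of the 4 values shown sits.

The compounds shown do not tell whether this result belongs to cyano specifically or would follow from replacing trifluoromethyl at this place with other groups, such as a methoxy group, an amine or a plain hydrogen. As far as these compounds go, whether the same exchange would have a similar effect on a different core, such as that of compound 2, also stays open.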